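This account rests on a few compounds, and the source may have more. Where it says the series, first, only, none or still open, it means among the compounds named here.

In a functional assay on Jurkat cells (Homo sapiens) for antiproliferative activity, read by MTT assay, with a stated time of 72 h (on this read-out higher numbers stand for weaker inhibition and lower numbers for stronger inhibition), compound 1 (`COc1cc(-n2ncnc2-c2ccc(C)cc2)cc(OC)c1OC`) gives 300 nM. Compound 2 (`COc1cc(-c2ncnn2-c2ccc(Cl)cc2Cl)cc(OC)c1OC`) stands at > 10000 nM, which is a limit and not a number. Compound 3 (`COc1cccc(-c2ncnn2-c2cc(OC)c(OC)c(OC)c2)c1`) likewise stands at a limit, > 10000 nM. The upper edge of the data is therefore (the limit of > 10000 nM in this assay, at which 2 of the 3 values shown sit), and compound 2 sits on it.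

Compound 4 (`COc1cc(-c2ncnn2-c2ccc(Cl)cc2)cc(OC)c1OC`) differs from compound 2 by a single change, (hydrogen in place of chloro on an aromatic carbon), turning 2,4-dichlorophenyl into 4-chlorophenyl. For the measured compounds named here, no measured step makes this same change. The nearest guide is an at least 33-fold higher number from compound 1 to compound 3 (1.52 log units; beyond the scatter), which shows that swapping one substituted phenyl group for another can be a large step in this series. The compound with a measured number, compound 1, also carries a single group on that phenyl ring as 4-methylphenyl, so a move towards a lower number is expected, though compound 4 may well stay at the limit. The expected change is an at least 3.3-fold lower number from compound 2 to compound 4 (0.52 log units; beyond the scatter). For compound 4, the estimated value is 3000 nM, with an expected range of 500 nM to 10000 nM.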

Compound 4, half-maximal inhibitory concentration: > 10000 nM
Compound 4: no number, only a limit (the forecaster's own chance of this, stated with the estimate: 40%); at least 3.3-fold (0.52 log units) between middle value and limit.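

In this assay, for the compounds shown here, compound 2 and compound 4 both stand at a limit and not at a number, so no step between them can be read: the limit of > 10000 nM in this assay, at which 3 of the 4 values shown sit. The compounds shown leave open how far 2,4-dichlorophenyl and 4-chlorophenyl differ in this series.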